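Notes on the step from compound 1 to compound 4

The source may hold more compounds than are shown below. What is called first, only, known or untested is meant among the compounds shown, and "the series" means these compounds.

Measured in a functional assay on L1210 cells (Mus musculus) for inhibition, with a stated time of 48 h; on this read-out higher numbers stand for weaker inhibition and lower numbers for stronger inhibition:
- compound 1 `CCNCCCNCCCN`: > 100000 nM
- compound 2 `CCNCCCNCCCNCC`: > 100000 nM
- compound 3 `CCNCCCNCCCCN`: > 100000 nM

Compound 1 stands at > 100000 nM, which is a limit of the assay and not a number. The same holds across the series, as the limit of > 100000 nM in this assay, at which 3 of the 3 values shown sit, shows. Compound 4 `CCNCCCCNCCCN` differs from compound 1 by (ethylamino)methyl in place of ethylamino on a saturated chain carbon, three bonds along the chain from an amine nitrogen. Within the data shown here, two measured steps bear on this change: a step that the two limits leave unreadable from compound 1 to compound 2 and a step that the two limits leave unreadable from compound 1 to compound 3. Neither gives a size or a direction to carry over. The expectation rests on compound 3, whose > 100000 nM is likewise a limit. The expected outcome is a step that the limit leaves unreadable from compound 1 to compound 4, most likely another limit, with no readable direction. For compound 4 the estimated value is 150000 nM, with an expected range of 60000 nM to 400000 nM.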

Compound 4, half-maximal inhibitory concentration: > 100000 nM
Compound 4 gave a limit, no number (the forecaster's own chance of this, stated with the estimate: 85%); the middle value is on the limit's open side.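

Among these compounds, compound 4 gives > 100000 nM, a limit and not a number, so no step from compound 1 to compound 4 can be read. The compounds shown leave open whether any of these chain changes alters inhibition: the limit of > 100000 nM in this assay, at which 4 of the 4 values shown sit.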